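Replacing a Pyridyl Alkyne with a Benzyl Sulfide

A few compounds are considered here, and "the series" means these few. Any claim that something is new, unique, unknown or untested is made for them only; others in the source may bear on it.

Among the compounds with values here, compound 1 `O=C(CCCCC#Cc1ccccn1)c1ncc(-c2ccccn2)o1` has the higher of the two numbers measured so far in an assay for inhibition of Fatty-acid amide hydrolase 1 (Rattus norvegicus) (a lower number here means a stronger inhibitor, a higher number a weaker inhibitor), where compound 1 gives 280 nM and compound 2 `O=C(CCCCC#Cc1cccc([N+](=O)[O-])c1)c1ncc(-c2ccccn2)o1` gives 4.8 nM; the gap between them is a 58-fold lower number from compound 1 to compound 2 (1.77 log units; beyond the scatter). Compound 3 `O=C(CCCCSCc1ccccc1)c1ncc(-c2ccccn2)o1` differs from compound 1 by benzylsulfanyl in place of 2-(pyridin-2-yl)ethynyl on a saturated chain carbon, four bonds along the chain from a carbonyl carbon. Within the data shown here, the one measured step swaps only the aromatic ring and keeps the linker, so it bears on compound 3 only loosely, though it shows that this part of the molecule moves the number strongly. A moderate improvement is therefore expected, a 5.6-fold lower number from compound 1 to compound 3 (0.75 log units; beyond the scatter). Compound 3 is estimated at 50 nM, between 8 nM and 300 nM.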

Compound 3, inhibition constant: 25 nM
Beside the measured number, compound 3's estimate is 2.0-fold (0.30 log units) above it, within the range that was stated.
By their numbers in this assay, from the lowest: compound 2; then compound 3; then compound 1.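

In this assay, replacing the whole 2-(pyridin-2-yl)ethynyl group with benzylsulfanyl gives an 11-fold lower number from compound 1 to compound 3 (1.05 log units; beyond the scatter). A triple bond is therefore not needed for a lower number at this chain carbon, since a sulfur-containing group with a carbon-only aromatic ring also gives one. No available measurement explains this gain.

The linker and the ring change together here, leaving their separate contributions unresolved. A pyridin-2-ylmethylsulfanyl group would keep the sulfur linker while restoring the pyridine ring, and a longer chain would test the spacing from the carbonyl.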